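One More Methoxy: From Compound 2 to Compound 3

This account rests on a few compounds, and the source may have more. Where it says the series, first, only, none or still open, it means among the compounds named here.

Compound 1 `CC(C)Cc1ccc(C(=O)/C=C/c2ccc(C(=O)O)cc2)cc1`: < 10 ug/mL
Compound 2 `COC(=O)c1cc(-c2cccc(NC(=O)c3ccc(/C=C/C(=O)c4cccc(OC)c4)cc3)c2)on1`: > 100 ug/mL

Of the compounds shown here, two have so far been read in an ADME assay on Vero cells (Chlorocebus sabaeus) for cytotoxicity, read by MTT assay, with a stated time of 72 h; on this read-out lower numbers stand for higher toxicity in this test and higher numbers for lower toxicity in this test. For compound 1 the reading < 10 ug/mL is a limit of the test rather than a number (the limit of < 10 ug/mL in this assay, at which 1 of the 2 values shown sits). For compound 2 the reading > 100 ug/mL is likewise a limit of the test (the limit of > 100 ug/mL in this assay, at which 1 of the 2 values shown sits). Among the compounds with values here, the two compounds do not differ in a single place, so no step between them can be measured; each simply shows its own limit.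

Compound 3 `COC(=O)c1cc(-c2cccc(NC(=O)c3ccc(/C=C/C(=O)c4ccc(OC)c(OC)c4)cc3)c2)on1` is the next compound to be tested in this assay. It differs from compound 2 by methoxy in place of hydrogen on an aromatic carbon. No measured step of this kind exists among the compounds shown, so the expected change from compound 2 to compound 3 is a number no higher from compound 2 to compound 3 (the limit leaves the size open), which is not expected to exceed the usual scatter in either direction. Compound 3 is therefore estimated at 100 ug/mL, with a range from 50 ug/mL to 200 ug/mL.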

Compound 3, half-maximal cytotoxic concentration: > 50 ug/mL
Compound 3: a limit, no number; the forecaster's own chance of this, stated with the estimate: 70%; the middle value does not contradict the limit.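

Within the data shown here, compound 2 and compound 3 each carry a limit of the test rather than a number, so no step between them can be read. As far as these compounds go, whether going from 3-methoxyphenyl to 3,4-dimethoxyphenyl changes the reading in this assay, and in which direction, stays open.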